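Removing trifluoromethyl from the nitro anilide

This account rests on a few compounds, and the source may have more. Where it says the series, first, only, none or still open, it means among the compounds named here.

- compound 1 `O=C(CCCCC(S)CCS)Nc1ccc(OC(F)(F)F)cc1` gives 49.7% in a functional assay on Bel-7402 cells (Homo sapiens) for inhibition, read by MTT assay, with a stated time of 24 h, tested at 100 ug/mL; a lower number here means less inhibition of growth, a higher number more inhibition of growth at the concentration tested
- compound 2 `O=C(CCCCC(S)CCS)Nc1ccc([N+](=O)[O-])c(C(F)(F)F)c1` gives 91.7% in this assay

Working notes. Of the two measured compounds, compound 2 stands highest at 91.7% in this assay, and compound 1 lies beyond the scatter under it. The next compound is compound 3 `O=C(CCCCC(S)CCS)Nc1ccc([N+](=O)[O-])cc1`, which is still to be measured. The change from compound 2 is hydrogen in place of trifluoromethyl on an aromatic carbon. Among the measured compounds shown here, no measured pair isolates this change, since compound 1 and compound 2 differ in more than one place. Only their two values are available as a guide. The expected direction is downward, and the estimated step is a number 21.7 percentage points lower from compound 2 to compound 3 (beyond the scatter) in this assay, although a result within the scatter of compound 2 would not be surprising. This expectation rests on compound 2 at 91.7% leaving little room upward, and on compound 1 at 49.7% showing how much lower a close analogue can read. The expected value for compound 3 is 70% in this assay, with an estimated range from 45% to 90% as the working bounds.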

Compound 3, percent growth inhibition at one concentration: 33.4%
Beside the measured number, compound 3's estimate is 36.6 percentage points above it; measured number outside the range, below it.
By their numbers in this assay, from the lowest: compound 3; then compound 1; then compound 2.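

In this assay, among the compounds shown here, the reading of the nitro anilide depends strongly on what sits on this aromatic carbon, ortho to a nitro group: hydrogen in place of trifluoromethyl gives a number 58.3 percentage points lower from compound 2 to compound 3 (beyond the scatter), and this is the first pair that isolates the change. The nitro group alone does not account for the high reading of compound 2, and with no trifluoromethyl on the ring, nitro in place of trifluoromethoxy on an aromatic carbon gives a number 16.3 percentage points lower from compound 1 to compound 3 (beyond the scatter), so the swap of these two groups also registers, though by less. No measurement on hand bears on why the loss of trifluoromethyl has so large an effect in this series.

A methyl, a chlorine or a nitrile on this same aromatic carbon would show whether the high reading is particular to trifluoromethyl or is shared by other groups in that place. Still open, from the compounds shown here alone, is whether the step keeps its size when the nitro group gives way to an amine, or when the chain carrying the two thiols is shortened.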